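Fluoro for Chloro on a Cytotoxic Thioether Series

The compounds below may be only part of what the source reports. "The series", "measured", "known", "first", "only" and "open" are said of these compounds alone.

Measured in a functional assay on LNCaP cells (Homo sapiens) for cytotoxicity, read by MTT assay; a higher number here means a weaker inhibitor, a lower number a stronger inhibitor:
- Compound 1 `COc1ccc2cc([C@H](C)c3nnc(SCc4ccc(Cl)cc4)n3-c3ccc(F)cc3)ccc2c1`: > 400000 nM (a limit)
- Compound 2 `COc1ccc2cc([C@H](C)c3nnc(SCc4ccc(C)cc4)n3-c3ccc(F)cc3)ccc2c1`: <= 400000 nM (a limit)
- Compound 3 `COc1ccc2cc([C@H](C)c3nnc(SCc4ccc(F)cc4)n3-c3ccc(Cl)cc3)ccc2c1`: 33900 nM

For the measured compounds named here, compound 3 stands alone in this assay as the only compound with an actual number, at 33900 nM. The entries for the other two compounds are limits and not numbers.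

The next compound to be tested is compound 4 `COc1ccc2cc([C@H](C)c3nnc(SCc4ccc(F)cc4)n3-c3ccc(F)cc3)ccc2c1`. It differs from compound 3 by one exchange, (fluoro in place of chloro on an aromatic carbon), which turns 4-chlorophenyl into 4-fluorophenyl.

Going by the values given here, only one measured step exists, a number no higher from compound 1 to compound 2 (the limit leaves the size open), where methyl takes the place of chloro on an aromatic carbon. Its size cannot be read, and it is not the same exchange, so it gives no direct measure for this one.

The closest hint is indirect. The 4-fluorophenyl group of compound 4 is already present in compound 1, whose > 400000 nM is a limit. Compound 2 carries the same group, and its <= 400000 nM is also a limit. On that slender basis, a weaker result is expected, meaning a higher number, though the size is very uncertain.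

The expected change is a 2.1-fold higher number from compound 3 to compound 4 (0.31 log units; beyond the scatter). For compound 4 the estimated value is 70000 nM, with an expected range from 20000 nM to 350000 nM.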

Compound 4, half-maximal inhibitory concentration: 104000 nM
Beside the measured number, compound 4's estimate is 1.5-fold (0.17 log units) below it; the measured number falls inside the stated range.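

For the compounds shown here, with compound 4, fluoro in place of chloro at this position has a readable size for the first time in this assay: a 3.1-fold higher number from compound 3 to compound 4 (0.49 log units; beyond the scatter), so the chloro group of compound 3 is the better of the two halogens here. The same exchange made at the other 4-chlorophenyl group, the one carried by compound 1, runs the opposite way, an at least 3.8-fold lower number from compound 1 to compound 4 (0.58 log units; beyond the scatter), which shows that among these compounds the direction of this exchange depends on which of the two places it is made in. The entry for compound 1 is a limit and not a number, so that second step has only a lower bound on its size: the limit of > 400000 nM in this assay, at which 1 of the 4 values shown sits.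

The step between compound 2 and compound 4 cannot be read, and the values shown do not tell why one exchange gives opposite results at the two places. As far as these compounds go, it also stays open whether an amine, a nitrile or a trifluoromethyl group in place of the chloro of compound 3 would give a lower number than the halogens do.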